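The source may hold more compounds than are shown below. What is called first, only, known or untested is meant among the compounds shown, and "the series" means these compounds.

Measured compounds and their values in a functional assay on RAW264.7 cells (Mus musculus) for inhibition, read by ELISA, with stated times of 30 min and 24 h; a higher number here means a weaker inhibitor, a lower number a stronger inhibitor:
compound 1 `CN1CCN(c2ccc(NC(=O)c3cc4cc(NC(=O)N(C)C)ccc4n3Cc3ccc(C(F)(F)F)cc3)cc2)CC1`: 1240 nM
compound 2 `CN1CCN(c2ccc(NC(=O)c3cc4cc(N)ccc4n3Cc3ccc(C(F)(F)F)cc3)cc2)CC1`: "not active" (no number reported)
compound 3 `CN1CCN(c2ccc(NC(=O)c3cc4cc(NC(=O)c5ccco5)ccc4n3Cc3ccc(C(F)(F)F)cc3)cc2)CC1`: 2900 nM

Compound 3 gives the higher of the two numbers reported in this assay; its nearest neighbour is compound 1, and the step of a 2.3-fold higher number from compound 1 to compound 3 (0.37 log units; beyond the scatter) lies beyond the scatter. For compound 2 no number was reported in this assay.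

Compound 4 `C=CC(=O)Nc1ccc2c(c1)cc(C(=O)Nc1ccc(N3CCN(C)CC3)cc1)n2Cc1ccc(C(F)(F)F)cc1` differs from compound 3 at a single place: vinyl in place of furan-2-yl on a carbonyl carbon. Going by the values given here, the only measured step that bears on this position is a 2.3-fold higher number from compound 1 to compound 3 (0.37 log units; beyond the scatter), a modest change when one group on that carbonyl carbon is exchanged for another. Nothing measured involves vinyl, so the direction for compound 4 is open; compound 2, which carries no acyl group at all, shows only that the substituent at this position matters. A step of similar modest size to the one already seen is therefore expected, most likely back toward the number of compound 1. Compound 4 is estimated at 1500 nM in this assay, within 400 nM to 5000 nM, meaning an expected step of a 1.9-fold lower number from compound 3 to compound 4 (0.29 log units; within the scatter).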

Compound 4, half-maximal inhibitory concentration: 6280 nM
Compound 4: the middle estimate sits 4.2-fold (0.62 log units) below what was measured, outside the stated range (above it).
By their numbers in this assay, from the lowest: compound 1; then compound 3; then compound 4.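

In this assay, the vinyl group does not return the number toward that of compound 1, as two steps show: a 2.2-fold higher number from compound 3 to compound 4 (0.34 log units; beyond the scatter) and a 5.1-fold higher number from compound 1 to compound 4 (0.70 log units; beyond the scatter). On this carbonyl carbon, the three groups with numbers therefore run in the order dimethylamino, furan-2-yl, vinyl, and each step in that order lies beyond the scatter, so the choice of group changes the number even though all three steps are modest. No measurement available here accounts for this order.

From the compounds shown here alone, it remains open whether the double bond of vinyl matters, which ethyl on the same carbonyl carbon would test. Going by these compounds, it is also open whether a longer chain, a phenyl ring or a morpholine group there would give a number lower than that of compound 1.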